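A longer unsaturated chain on compound 3

The source may report more compounds than this note shows. Statements on the series, on what has been measured and on what is new or still open speak of the compounds shown alone.

Three amides of a shared core have been measured in a functional assay on WM164 cells (Homo sapiens) for antiproliferative activity, read by sulforhodamine B assay, with a stated time of 48 h; on this read-out higher numbers stand for weaker inhibition and lower numbers for stronger inhibition. Compound 1 `CCCCCCCCNC(=O)[C@@H]1CSC(c2cc(OC)c(OC)c(OC)c2)N1` gives 19600 nM, compound 2 `CCCCCCCCCCCCNC(=O)[C@@H]1CSC(c2ccc(OC)c(OC)c2)N1` gives 1600 nM and compound 3 `CCCCCCCCCCCCCCCNC(=O)[C@@H]1CSC(c2ccc(NC(C)=O)cc2)N1` gives 1000 nM. Compound 3 thus lies within the scatter of compound 2 and well clear of compound 1, whose number is far higher.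

Compound 4 `CCCCCCCCC/C=C\CCCCCCCNC(=O)[C@@H]1CSC(c2ccc(NC(C)=O)cc2)N1` keeps everything in compound 3 except the end of the chain: a group of 11 heavy atoms (11 carbon; no ring) in place of a group of 8 heavy atoms (8 carbon; no ring), on a saturated chain carbon, seven bonds along the chain from an amide-type nitrogen. Going by the values given here, no two measured compounds differ in one place only, so the data offer no direct guide to this change. Compound 2 at 1600 nM and compound 3 at 1000 nM differ in both chain and aromatic substituents, yet remain within the scatter of each other. No change beyond the scatter is therefore expected in this assay. The estimated step is a 1.5-fold higher number from compound 3 to compound 4 (0.18 log units; within the scatter), toward a slightly higher number. For compound 4 the expected value is 1500 nM, with an estimated range from 500 nM to 4500 nM.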

Compound 4, half-maximal inhibitory concentration: 1000 nM
Estimate against measurement, compound 4: 1.5-fold (0.18 log units) above; the range from low to high includes it.
By their numbers in this assay, from the lowest: compounds 3, 4 and 2 (each within the scatter of the next); then compound 1.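

In this assay, going by these compounds alone, there is no change at the digits printed from compound 3 to compound 4 (within the scatter) and this is the first comparison of compounds that differ in one place only. It shows that on a saturated chain carbon, seven bonds along the chain from an amide-type nitrogen, octyl can give way to a group of 11 heavy atoms with 1 double bond outside aromatic rings without a change beyond the scatter. Nothing measured here explains why the number holds.

As far as these compounds go, what a fully saturated chain of the same length would give on this core remains open, as does a chain ending in an amine or a carboxylic acid. Also open, from the compounds shown here alone, is whether the same exchange would leave the number unchanged with the aromatic substituents of compound 2.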